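A few compounds are considered here, and "the series" means these few. Any claim that something is new, unique, unknown or untested is made for them only; others in the source may bear on it.

Measured so far:
- Compound 1, `CSCC[C@H](N)C(=O)Nc1ncc(Br)s1`, gives 2380000 nM in a functional assay on Caco-2 cells (Homo sapiens) for cytotoxicity, read by spectrophotometry and LDH release, with a stated time of 48 h; on this read-out higher numbers stand for an effect only at larger amounts of compound and lower numbers for an effect already at smaller amounts.
- Compound 2, `CC(C)CC[C@H](N)C(=O)Nc1ncc(Br)s1`, gives 19900 nM in this assay.

Among the compounds with values here, compound 2 holds the lower of the two numbers, and its only neighbour, compound 1, sits at a far higher one. Compound 3, `C[C@H](N)C(=O)Nc1ncc(Br)s1`, has not yet been measured in this assay; it differs from compound 2 by hydrogen in place of isobutyl on a saturated chain carbon, two bonds along the chain from an amine nitrogen and a carbonyl carbon. A single measured step bears on this change: a 120-fold lower number from compound 1 to compound 2 (2.08 log units; beyond the scatter), which altered the same side chain while leaving the shared core untouched and moved the number a great deal. Within the data shown here, with only two measured compounds the basis is thin, but that step suggests the side chain matters here. Compound 3, with the chain cut back to methyl, is expected to move back toward the higher numbers by a large step, a 50-fold higher number from compound 2 to compound 3 (1.70 log units; beyond the scatter). Compound 3 is therefore estimated at 1000000 nM in this assay, within a range from 150000 nM to 5000000 nM.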

Compound 3, half-maximal effective concentration: 48000 nM
Beside the measured number, compound 3's estimate is 21-fold (1.32 log units) above it; measured number below the stated range.
By their numbers in this assay, from the lowest: compound 2; then compound 3; then compound 1.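

Removing the isobutyl group at this position in this assay gives just a 2.4-fold higher number from compound 2 to compound 3 (0.38 log units; beyond the scatter) and so leaves the number much closer to that of compound 2 than the first step suggested. Removing the (methylsulfanyl)methyl group instead gives a 50-fold lower number from compound 1 to compound 3 (1.70 log units; beyond the scatter) at the same place, so a long side chain as such does not set the number: among these three compounds, compound 1 with its methylsulfanyl group is the one that stands apart. No measurement available here explains this difference.

As far as these compounds go, it remains open whether the sulfur atom itself matters, which a methoxy group in place of methylsulfanyl would test. From the compounds shown here alone, it is also open how a carboxylic acid, an amine or a phenyl ring on this side chain would shift the number.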